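Aryl swap on a shared core with weak cytotoxicity

The source may hold more compounds than are shown below. What is called first, only, known or untested is meant among the compounds shown, and "the series" means these compounds.

Going by the values given here, compound 3 `N#CC1=C(N)OC(c2c[nH]c3ccccc23)=C(C#N)C1c1ccc2ccccc2c1` is the only one of the three compounds with a number in a functional assay on MCF7 cells (Homo sapiens) for cytotoxicity, read by MTT assay, with a stated time of 24 h (a higher number here means that more compound is tolerated, a lower number that less compound is tolerated), where compound 3 gives 91500 nM. Compound 1 `N#CC1=C(N)OC(c2c[nH]c3ccccc23)=C(C#N)C1c1ccccc1F` reaches only a limit of the assay in this assay, > 100000 nM. Compound 2 `N#CC1=C(N)OC(c2c[nH]c3ccccc23)=C(C#N)C1c1ccc(Br)cc1` likewise reaches only a limit in this assay, > 100000 nM. The step of an at least 1.0-fold lower number from compound 1 to compound 3 (0.03 log units; that floor lies within the scatter) and the step of an at least 1.0-fold lower number from compound 2 to compound 3 (0.03 log units; that floor lies within the scatter) are therefore floors only, and the step that the two limits leave unreadable from compound 1 to compound 2 cannot be read. The evidence on these steps is the limit of > 100000 nM in this assay, at which 2 of the 3 values shown sit. Compound 4 `COc1ccc(C2C(C#N)=C(N)OC(c3c[nH]c4ccccc34)=C2C#N)cc1OC` differs from compound 3 by 3,4-dimethoxyphenyl in place of naphthalen-2-yl on a saturated ring carbon. The aryl swaps already measured on this saturated ring carbon gave no movement that could be read as beyond the scatter, so in this assay the step is expected to be a 1.1-fold higher number from compound 3 to compound 4 (0.04 log units; within the scatter). Compound 4 is therefore expected to give about 100000 nM, within 50000 nM to 250000 nM, with a fair chance that only a limit is reported.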

Compound 4, concentration lethal to 50% of the cells: 72100 nM
Estimate against measurement, compound 4: 1.4-fold (0.14 log units) above, and the stated range covers the measured number.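

Going by these compounds alone, with a number at both ends, the change from naphthalen-2-yl to 3,4-dimethoxyphenyl gives the first fully readable step on this saturated ring carbon in this assay: a 1.3-fold lower number from compound 3 to compound 4 (0.10 log units; within the scatter). Replacing two aromatic rings of carbon with one that carries hydrogen-bond acceptors therefore produces no movement beyond the scatter here. Only floors can be read for the other two changes, an at least 1.3-fold lower number from compound 2 to compound 4 (0.14 log units; that floor lies within the scatter) and an at least 1.3-fold lower number from compound 1 to compound 4 (0.14 log units; that floor lies within the scatter), because their starting values stop at an assay limit: the limit of > 100000 nM in this assay, at which 2 of the 4 values shown sit.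

Going by these compounds, whether any group on this carbon can move the number beyond the scatter remains open, including an aryl ring bearing an amine or a carboxylic acid. Also open, on these data alone, is what a change at the ring atom that bears the 1H-indol-3-yl group would do.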